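The source may report more compounds than this note shows. Statements on the series, on what has been measured and on what is new or still open speak of the compounds shown alone.

Measured so far:
compound 1 `CCOCCCNC(=O)c1ccc(-n2c(-c3ccccc3)nc3cccnc32)cc1` — 26.1%
compound 2 `Cc1ccc(C)c(OCc2nc(C)c(C(=O)Nc3cccc(Cl)c3)s2)c1` — 17.1%

The study examined two compounds in an assay for binding affinity to CDK8/Cyclin C (Homo sapiens), read by FRET and LanthaScreen, with stated times of 20 min and 2 h, tested at 10 uM; on this read-out lower numbers stand for less inhibition and higher numbers for more inhibition at the one concentration tested (going by the name of the read-out). Compound 1 `CCOCCCNC(=O)c1ccc(-n2c(-c3ccccc3)nc3cccnc32)cc1` gave 26.1% in this assay, and compound 2 `Cc1ccc(C)c(OCc2nc(C)c(C(=O)Nc3cccc(Cl)c3)s2)c1` gave 17.1%. Compound 1 holds the higher of the two numbers, but the gap to compound 2 lies within the usual scatter of repeated measurements, so the two values cannot be told apart with confidence. Among the measured compounds shown here, no pair of compounds differing in a single place has been measured, so no step can yet be read from the data.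

Compound 3 `O=C(NCc1cccnc1)c1ccc(-n2c(-c3ccccc3)nc3cccnc32)cc1` is the next compound to be measured in this assay. It differs from compound 1 in one place: pyridin-3-yl in place of 2-ethoxyethyl on a saturated chain carbon bound to an amide-type nitrogen. The change keeps the amide and the whole shared core of compound 1 and replaces only the group on the saturated chain carbon bound to the amide-type nitrogen. For the measured compounds named here, with no measured step of this kind to draw on, the expected step from compound 1 to compound 3 is a number 1.1 percentage points lower from compound 1 to compound 3 (within the scatter), that is, none beyond the scatter. Compound 3 is estimated to give 25% in this assay, with a range from 8% to 42%.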

Compound 3, a percentage reported as inhibition, at one concentration (the size of the read-out at that concentration, not a potency): 38.9%
Beside the measured number, compound 3's estimate is 13.9 percentage points below it, and the stated range covers the measured number.
By their numbers in this assay, from the lowest: compounds 2 and 1 (each within the scatter of the next); then compound 3.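

In this assay, this position on a saturated chain carbon bound to an amide-type nitrogen proves responsive to change: pyridin-3-yl in place of 2-ethoxyethyl gives a number 12.8 percentage points higher from compound 1 to compound 3 (beyond the scatter). Among the compounds shown here, this is the first single-place step that can be read, and although modest, it shows that an open chain with no ring can give way to a six-membered aromatic ring with one hetero atom, with the amide and the shared core left as they are, without any loss in the number. Nothing available accounts for the size or direction of this step.

The compounds shown leave open whether the step belongs to the ring as a whole or to its ring nitrogen, and a phenyl group in the same place, with carbon in place of that nitrogen, would separate the two readings. On these data alone, whether a longer chain between the amide nitrogen and the pyridin-3-yl ring would keep the step also remains open, and a single step at one concentration does not establish a trend at this position.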